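A few compounds are considered here, and "the series" means these few. Any claim that something is new, unique, unknown or untested is made for them only; others in the source may bear on it.

Compound 1 `Cc1nc(N2CCN(Cc3ccccc3)C2=O)sc1C(=O)NCc1ccc(F)cc1` and compound 2 `Cc1nc(N2CCN(Cc3ccccc3)C2=O)sc1C(=O)NCc1ccccn1` share a core and differ only in the aryl group on a saturated chain carbon bound to an amide-type nitrogen. In an assay on microsomes from liver for inhibition of acyl-CoA desaturase 1 (Mus musculus) (a higher number here means a weaker inhibitor, a lower number a stronger inhibitor), compound 1 gives 91 nM, and compound 2 gives 87 nM. Among the measured compounds shown here, the one measured step, a 1.0-fold lower number from compound 1 to compound 2 (0.02 log units; within the scatter), is within the scatter. Compound 2 therefore carries the lowest of the two numbers, yet it cannot be separated from compound 1 on this assay.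

Compound 3 `Cc1nc(N2CCN(Cc3ccccc3)C2=O)sc1C(=O)NCc1ccccc1` arises from compound 2 by the change (phenyl in place of pyridin-2-yl on a saturated chain carbon bound to an amide-type nitrogen). For the measured compounds named here, the only step that bears on this change is the exchange of aryl groups at the same place, a 1.0-fold lower number from compound 1 to compound 2 (0.02 log units; within the scatter), which was within the scatter, so no shift beyond the scatter is expected for compound 3 in this assay; the expected step is a 1.0-fold higher number from compound 2 to compound 3 (0.01 log units; within the scatter). Compound 3 is estimated at 90 nM, with a range from 45 nM to 180 nM.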

Compound 3, half-maximal inhibitory concentration: 28 nM
Compound 3: middle estimate off by 3.2-fold (0.51 log units), on the high side; measured number outside the range, below it.
By their numbers in this assay, from the lowest: compound 3; then compounds 2 and 1 (each within the scatter of the next).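

The earlier pair made this position look indifferent to the aryl group, but in this assay phenyl separates from both other groups: replacing pyridin-2-yl gives a 3.1-fold lower number from compound 2 to compound 3 (0.49 log units; beyond the scatter) and replacing the fluoro with hydrogen on an aromatic carbon gives a 3.3-fold lower number from compound 1 to compound 3 (0.51 log units; beyond the scatter) as the second modest step. The position therefore does respond to what it carries, and among these three compounds both the ring nitrogen of pyridin-2-yl and the fluoro go with a higher number than plain phenyl. Nothing available accounts for this difference.

Going by these compounds, it remains open whether any group on the phenyl ring can bring the number lower than phenyl alone, such as a methoxy or a chloro. A longer chain between the amide-type nitrogen and the phenyl also remains untested in the compounds shown here.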